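The source may report more compounds than this note shows. Statements on the series, on what has been measured and on what is new or still open speak of the compounds shown alone.

Values so far in a functional assay on MDA-MB-231 cells (Homo sapiens) for antiproliferative activity, read by CCK-8 assay, with a stated time of 48 h; on this read-out higher numbers stand for weaker inhibition and lower numbers for stronger inhibition:
- compound 1 `CNC(=O)/C=C/CN1CC(Oc2ccc(Oc3c(-c4ccc(F)cc4)sc4cc(O)ccc34)cc2)C1` gives > 50000 nM, a limit
- compound 2 `C=CC(=O)NCCOc1ccc(Oc2c(-c3ccc(F)cc3)sc3cc(O)ccc23)cc1` gives > 50000 nM, a limit
- compound 3 `O=C(CCCNCCOc1ccc(Oc2c(-c3ccc(F)cc3)sc3cc(O)ccc23)cc1)N1CCC1` gives > 50000 nM, a limit

Compound 1 has only a limit and no number, and the picture for the whole set is the limit of > 50000 nM in this assay, at which 3 of the 3 values shown sit, and nothing more. Compound 4 `O=C(/C=C/CN1CC(Oc2ccc(Oc3c(-c4ccc(F)cc4)sc4cc(O)ccc34)cc2)C1)N1CCC1` is not yet measured. It departs from compound 1 in one place, on a carbonyl carbon, where methylcarbamoyl becomes (azetidin-1-yl)carbonyl: azetidin-1-yl in place of methylamino on a carbonyl carbon. The nearest measured comparison is a step that the two limits leave unreadable from compound 1 to compound 3, and it too brings in an azetidin-1-yl on a carbonyl carbon. The same holds for a step that the two limits leave unreadable from compound 2 to compound 3. Neither gives a size that could be carried over. Compound 3, which carries this amide, gives > 50000 nM as a limit. On that basis no shift beyond the usual scatter, in either direction, is expected in this assay, and the expected move is a number no higher from compound 1 to compound 4 (the limit leaves the size open) in all. For compound 4 the estimate is 50000 nM, with an expected range from 20000 nM to 100000 nM, and a bare limit is again the likeliest report.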

Compound 4, half-maximal inhibitory concentration: > 50000 nM
Compound 4 gave a limit, no number; the forecaster's own chance of this, stated with the estimate: 85%; the middle value sits exactly at the limit.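

In this assay compound 4 gives > 50000 nM, which is a limit and not a number. Among the compounds shown here, compound 1 also has only a limit, so no step from methylamino to azetidin-1-yl can be read between compound 1 and compound 4. The compounds shown leave open whether any of them differs from another in potency, as the set offers a single reading: the limit of > 50000 nM in this assay, at which 4 of the 4 values shown sit.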